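Series notes: aryl exchange at the exocyclic carbon

This account rests on a few compounds, and the source may have more. Where it says the series, first, only, none or still open, it means among the compounds named here.

In a functional assay on Huh-7 cells (Homo sapiens) for cytotoxicity, read by CCK-8 assay, with a stated time of 72 h (a higher number here means a weaker inhibitor, a lower number a stronger inhibitor), the measured members stand as follows:
compound 2 `C=CCn1c(=O)/c(=C\c2ccccc2Cl)[nH]c(=O)/c1=C\c1ccccc1OC`: 6400 nM
compound 3 `C=CCn1c(=O)/c(=C\c2ccccc2C(F)(F)F)[nH]c(=O)/c1=C\c1ccccc1OC`: 9500 nM
compound 1 `COc1ccccc1/C=c1/[nH]c(=O)/c(=C\c2ccccc2OC)n(C)c1=O`: "not active" (no number reported)

Compound 2 has the lowest of the two numbers; its nearest neighbour is compound 3, and the step of a 1.5-fold higher number from compound 2 to compound 3 (0.17 log units; within the scatter) lies within the scatter. Compound 1 gives no number at all in this assay. Compound 4 `C=CCn1c(=O)/c(=C\c2ccc(C)cc2)[nH]c(=O)/c1=C\c1ccccc1OC` differs from compound 2 by 4-methylphenyl in place of 2-chlorophenyl on a double-bonded chain carbon bound to an aromatic carbon. Within the data shown here, no measured step bears directly on this change: the only step, from compound 2 to compound 3, exchanges one group for another on the same ring, and compound 1, which carries no chloro, is the sole point with a different pattern. The expectation for compound 4 is therefore set at 10000 nM (range 4000 nM to 30000 nM), an expected step of a 1.6-fold higher number from compound 2 to compound 4 (0.19 log units; within the scatter) in this assay, with little support.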

Compound 4, half-maximal inhibitory concentration: "not active" (no number reported)
Nothing numeric was reported for compound 4, so the estimate cannot be set against anything.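

Among these compounds, compound 4 gives no number in this assay, so no step from compound 2 to compound 4 can be read, and no measured evidence bears on this result. Going by these compounds, how 4-methylphenyl in place of 2-chlorophenyl shifts the read-out remains open.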